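Amine variation on the aminoalkoxy chain

This account rests on a few compounds, and the source may have more. Where it says the series, first, only, none or still open, it means among the compounds named here.

In a functional assay on HepG2 cells (Homo sapiens) for antiproliferative activity, read by MTT assay, with a stated time of 48 h (a lower number here means a stronger inhibitor, a higher number a weaker inhibitor), compound 2 `O=c1cc(-c2ccccc2)oc2cc(OCc3ccccc3)c(OCCCCN3CCCC3)c(O)c12` gives 2000 nM, the lowest of the two numbers recorded; compound 1 `O=c1cc(-c2ccccc2)oc2cc(OCc3ccccc3)c(OCCCN3CCCC3)c(O)c12` gives 4200 nM. Compound 3 `CCN(CC)CCCCOc1c(OCc2ccccc2)cc2oc(-c3ccccc3)cc(=O)c2c1O` differs from compound 2 by diethylamino in place of pyrrolidin-1-yl on a saturated chain carbon, four bonds along the chain from an oxygen on an aromatic ring. Among the measured compounds shown here, no measured step changes the amine itself; the one step in hand lengthens the chain between the aromatic oxygen and the amine and reads a 2.1-fold lower number from compound 1 to compound 2 (0.32 log units; beyond the scatter), a modest change that bears only loosely on an exchange of one amine for another. For compound 3 the expected step is therefore a 1.3-fold higher number from compound 2 to compound 3 (0.10 log units; within the scatter), nothing beyond the scatter. Compound 3 is thus estimated at 2500 nM, within 1000 nM to 6000 nM.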

Compound 3, half-maximal inhibitory concentration: 2200 nM
Beside the measured number, compound 3's estimate is 1.1-fold (0.06 log units) above it; low and high end bracket the measured number.
By their numbers in this assay, from the lowest: compounds 2, 3 and 1 (each within the scatter of the next, the first and the last beyond it).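

In this assay, among the compounds shown here, the first exchange of the amine itself, diethylamino in place of pyrrolidin-1-yl, gives a 1.1-fold higher number from compound 2 to compound 3 (0.04 log units; within the scatter) and so shows that the ring can be opened at this position without a change that can be told from the scatter. With the chain change included, the comparison reads a 1.9-fold lower number from compound 1 to compound 3 (0.28 log units; within the scatter) and also stays within the scatter, whereas the chain change alone, a 2.1-fold lower number from compound 1 to compound 2 (0.32 log units; beyond the scatter), lay beyond it. No measured evidence bears on why the amine exchange reads this way. Still open, on these data alone, is whether morpholine or piperidine in place of these amines would separate from compound 2. A longer chain carrying either pyrrolidin-1-yl or diethylamino is equally unresolved.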